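A Single Fluoro Swap Tried on Two Related Cores

A few compounds are considered here, and "the series" means these few. Any claim that something is new, unique, unknown or untested is made for them only; others in the source may bear on it.

Compound 1 `C/C1=C\CC[C@@]2(C)O[C@@H]2[C@H]2OC(=O)[C@@H](CN3CCN(c4ccccc4)CC3)[C@@H]2C[C@H]1O` and compound 2 `C/C1=C\CC[C@@]2(C)O[C@@H]2[C@H]2OC(=O)[C@@H](CN3CCN(c4ccccc4F)CC3)[C@@H]2C[C@H]1O` share one core, while compound 3 `C[C@]12O[C@@H]1CC[C@@]1(C)O[C@@H]1[C@H]1OC(=O)[C@@H](CN3CCN(c4ccccc4)CC3)[C@@H]1C[C@H]2O` and compound 4 `C[C@]12O[C@@H]1CC[C@@]1(C)O[C@@H]1[C@H]1OC(=O)[C@@H](CN3CCN(c4ccccc4F)CC3)[C@@H]1C[C@H]2O` share another; the difference between the two cores is not broken down here. All were tested in a functional assay on Glioma cells (Homo sapiens) for inhibition, read by MTT assay, with a stated time of 72 h; a lower number here means a stronger inhibitor, a higher number a weaker inhibitor. Compound 1 gives 5000 nM and compound 2 gives 6000 nM. The change between them is fluoro in place of hydrogen on an aromatic carbon, and it made a 1.2-fold higher number from compound 1 to compound 2 (0.08 log units; within the scatter). Compound 3 gives 35000 nM, the highest number of the three measured; the gap to compound 2 and the gap to compound 1 both lie beyond the scatter.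

Compound 4 carries the same change on the core of compound 3: fluoro in place of hydrogen on an aromatic carbon. The place of the change is described in the same words for both pairs, so it counts as the same change. The step expected here is a 1.1-fold higher number from compound 3 to compound 4 (0.06 log units; within the scatter), because the same change earlier made a 1.2-fold higher number from compound 1 to compound 2 (0.08 log units; within the scatter). Compound 4 is therefore estimated to give about 40000 nM, with a likely range from 20000 nM to 90000 nM.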

Compound 4, half-maximal inhibitory concentration: 8000 nM
Compound 4: the middle estimate sits 5.0-fold (0.70 log units) above what was measured, and the stated range ends above it.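

In this assay the swap of phenyl to 2-fluorophenyl on the second core gave a 4.4-fold lower number from compound 3 to compound 4 (0.64 log units; beyond the scatter) and so did not repeat the size of the step seen on the first core. Set side by side, the two results differ by more than repeated measurements would explain: the same change on two cores in this assay, a 1.2-fold higher number (0.08 log units; within the scatter) from compound 1 to compound 2 and a 4.4-fold lower number (0.64 log units; beyond the scatter) from compound 3 to compound 4, 5.3-fold (0.72 log units) apart, beyond the scatter of two such steps. In this series, then, the step measured on one core was a poor guide to the step on the other, but two pairs do not show why the cores respond differently, or whether any other change would behave the same way.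

The compounds shown carry only hydrogen or fluoro at this one place on the aromatic ring, so it remains open whether a chloro, methyl or methoxy group there would also give a step that depends on the core. As far as these compounds go, it also remains open whether the two cores would differ in this way on other kinds of cells.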